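A few compounds are considered here, and "the series" means these few. Any claim that something is new, unique, unknown or untested is made for them only; others in the source may bear on it.

Compound 1 `O=C(CCCCC1CCSS1)NO` gives "not determined" (no result reported)
Compound 2 `O=C(CCCCC1CCSS1)Nc1ccc(OC(F)(F)F)cc1` gives 10.8%
Compound 3 `O=C(CCCCC1CCSS1)Nc1ccccn1` gives "not determined" (no result reported)

For the measured compounds named here, in a functional assay on PC-3 cells (Homo sapiens) for inhibition, read by MTT assay, with a stated time of 24 h, tested at 1 ug/mL (on this read-out higher numbers stand for more inhibition of growth at the one concentration tested and lower numbers for less inhibition of growth), compound 2 stands at 10.8% as the only number available, while compound 1 and compound 3 have no result, so no ranking is possible.

Compound 4 `O=C(CCCCC(S)CCS)Nc1ccc(OC(F)(F)F)cc1` has not yet been measured. It differs from compound 2 on a saturated chain carbon, four bonds along the chain from a carbonyl carbon. There, a group of 5 heavy atoms (3 carbon, 2 sulfur; no ring) in place of a group of 5 heavy atoms (3 carbon, 2 sulfur; one five-membered non-aromatic ring with 2 hetero atoms), on a saturated chain carbon, four bonds along the chain from a carbonyl carbon sums up the swap: the 1,3-disulfanylpropyl group, with no ring, takes the place of the five-membered non-aromatic ring.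

Going by the values given here, no measured pair of compounds shows what a change like this does, so the data give no direct guide to its size or direction. In this assay no step beyond the usual scatter is expected, and the expectation rests on compound 2 at 10.8% as the only measured reference.

Compound 4 is estimated at 14% with an expected range of 2% to 32% in this test. This estimate means an expected a number 3.2 percentage points higher from compound 2 to compound 4 (within the scatter) and the range stays wide, as one number is a thin base.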

Compound 4, percent growth inhibition at one concentration: 12.6%
For compound 4 the middle estimate is 1.4 percentage points above the measured one, within the range that was stated.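

In this assay, for the compounds shown here, replacing the five-membered non-aromatic ring with the open 1,3-disulfanylpropyl group gives a number 1.8 percentage points higher from compound 2 to compound 4 (within the scatter) and provides the first readable step at this place, on a saturated chain carbon, four bonds along the chain from a carbonyl carbon. Within this one test at a single concentration, the ring is therefore not shown to matter, and neither is the gain of hydrogen-bond donors that comes with the open group. Nothing shown here offers an explanation for this result.

The compounds shown leave open whether a larger change at this place, such as a carboxylic acid or a longer chain, would move growth inhibition beyond the scatter. They also leave open whether opening the ring would have the same outcome with the other groups on the amide nitrogen.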